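Sulfonyl aryl swap: human microsomal clearance notes

The compounds below may be only part of what the source reports. "The series", "measured", "known", "first", "only" and "open" are said of these compounds alone.

Three compounds have numbers in an ADME assay on microsomes from liver (Homo sapiens) for metabolic stability, tested at 2.5 uM; on this read-out higher numbers stand for fast clearance and lower numbers for slow clearance. Compound 1 `COc1ccc(-c2c(S(=O)(=O)c3cccc(C#N)c3)cnc3cc(F)ccc23)cc1` gives 0.92 mL/min. Compound 3 `COc1ccc(-c2c(S(=O)(=O)c3ccc(C)c(C)c3)cnc3cc(F)ccc23)cc1` gives 4.13 mL/min, and compound 2 `COc1cccc(-c2c(S(=O)(=O)c3ccc(C)c(C)c3)cnc3cc(F)ccc23)c1` gives 8.78 mL/min, the highest of the three. Compound 4 `COc1cccc(-c2c(S(=O)(=O)c3cccc(C#N)c3)cnc3cc(F)ccc23)c1` has not yet been measured in this assay.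

Two changes connect the measured compounds. The cores of compound 2 and compound 3 differ only by 3-methoxyphenyl in place of 4-methoxyphenyl on an aromatic carbon; that step is a 2.1-fold lower number from compound 2 to compound 3 (0.33 log units; beyond the scatter). The sulfonyl change, (3-cyanophenyl in place of 3,4-dimethylphenyl on a sulfonyl sulfur), made the step of a 4.5-fold lower number from compound 3 to compound 1 (0.65 log units; beyond the scatter).

Compound 4 carries the same sulfonyl change relative to compound 2, namely (3-cyanophenyl in place of 3,4-dimethylphenyl on a sulfonyl sulfur); the surroundings of the place are the same as in the measured pair, so it is taken as the same change. For the measured compounds named here, its only measured precedent is that single step, and one instance supports only a rough expectation. On that precedent, the expected step is a 4.4-fold lower number from compound 2 to compound 4 (0.64 log units; beyond the scatter). The estimate for compound 4 in this assay is 2 mL/min, with an expected range of 0.9 mL/min to 4.5 mL/min.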

Compound 4, intrinsic clearance in a liver preparation (reported as CLH), per the amount of preparation that the assay uses: 1.83 mL/min
Compound 4: the middle estimate sits 1.1-fold (0.04 log units) above what was measured; the measured number falls inside the stated range.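

In this assay the 3-cyanophenyl for 3,4-dimethylphenyl change on the sulfonyl sulfur gives a 4.8-fold lower number from compound 2 to compound 4 (0.68 log units; beyond the scatter) on the core bearing 3-methoxyphenyl, and it carries over from the core bearing 4-methoxyphenyl: the same change on two cores in this assay, a 4.5-fold lower number (0.65 log units; beyond the scatter) from compound 3 to compound 1 and a 4.8-fold lower number (0.68 log units; beyond the scatter) from compound 2 to compound 4, 1.1-fold (0.03 log units) apart, within the scatter of two such steps. The methoxyphenyl swap, read with 3-cyanophenyl on the sulfonyl sulfur, gives a 2.0-fold higher number from compound 1 to compound 4 (0.30 log units; within the scatter), and it too holds from one sulfonyl group to the other: the same change on two cores in this assay, a 2.1-fold lower number (0.33 log units; beyond the scatter) from compound 2 to compound 3 and a 2.0-fold lower number (0.30 log units; within the scatter) from compound 4 to compound 1, 1.1-fold (0.03 log units) apart, within the scatter of two such steps. Across these four compounds the two changes therefore add up without visible interaction, but that rests on only two cores per change and does not show why either step has its size or that it would hold on a core differing in any other place.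

The compounds shown leave open how the sulfonyl change would read with an aryl group carrying an amine or a carboxylic acid. Also open, going by these compounds, is whether the steps would survive replacing the fluorine on the shared core with chlorine.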